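Changing One Group on a Shared Aromatic Ring

A few compounds are considered here, and "the series" means these few. Any claim that something is new, unique, unknown or untested is made for them only; others in the source may bear on it.

compound 1 `N#Cc1c(Nc2ccc(C(F)(F)F)cc2)sc2ccccc12`: 24%
compound 2 `N#Cc1c(Nc2ccc(N)cc2)sc2ccccc12`: 1%

In a functional assay on HUVEC cells (Homo sapiens), read by fluorescence and microscopy, with a stated time of 6 h, tested at 10 uM (on this read-out lower numbers stand for a stronger effect and higher numbers for a weaker effect at the one concentration tested), compound 2 stands lowest of the two numbers shown, and the one measured step, a number 23 percentage points lower from compound 1 to compound 2 (beyond the scatter), lies beyond the scatter. Compound 3 `N#Cc1c(Nc2ccc(F)cc2)sc2ccccc12` differs from compound 2 by fluoro in place of amino on an aromatic carbon. Going by the values given here, no measured step involves fluoro, so the only guide is that step, which shows the group at this place moving the read-out across a modest span. A step back toward compound 1 is therefore expected, a number 11 percentage points higher from compound 2 to compound 3 (beyond the scatter), though its size is uncertain. Compound 3 is estimated at 12%, within a range of 0% to 35%.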

Compound 3, a percentage reported as activity, at one concentration (the size of the read-out at that concentration, not a potency): 25%
For compound 3 the middle estimate is 13 percentage points below the measured one; low and high end bracket the measured number.
By their numbers in this assay, from the lowest: compound 2; then compounds 1 and 3 (each within the scatter of the next).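

In this assay, fluoro in place of amino gives a number 24 percentage points higher from compound 2 to compound 3 (beyond the scatter), while fluoro in place of trifluoromethyl gives a number 1 percentage points higher from compound 1 to compound 3 (within the scatter). At this place on the aromatic ring, then, fluoro and trifluoromethyl read alike, and among these three groups only amino stands apart. No measurement shown here explains why amino differs from the other two. From the compounds shown here alone, it remains open whether a hydroxyl or a methylamino group at the same place would give a number close to that of compound 2 or close to those of compound 1 and compound 3.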